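Pentyl Addition on a Triazole Series Against Nitric Oxide Output

This account rests on a few compounds, and the source may have more. Where it says the series, first, only, none or still open, it means among the compounds named here.

Compound 1 `O=C(c1cc(-n2cc(-c3ccccc3)nn2)ccc1O)N1CCCCC1` and compound 2 `CCCCCc1ccc(-c2cn(-c3ccc(O)c(C(=O)N4CCCCC4)c3)nn2)cc1` share one core; compound 3 `CCCNC(=O)c1ccc(-n2cc(-c3ccccc3)nn2)cc1O` and compound 4 `CCCCCc1ccc(-c2cn(-c3ccc(C(=O)NCCC)c(O)c3)nn2)cc1` share another, and the difference between the two cores is not broken down here. In a functional assay on RAW264.7 cells (Mus musculus) for inhibition, read by Griess assay, with a stated time of 20 h (a lower number here means a stronger inhibitor, a higher number a weaker inhibitor), compound 1 gives only a limit, > 20000 nM. Compound 2 likewise reaches only a limit, > 20000 nM. Compound 3 also gives a limit, > 20000 nM. From compound 1 to compound 2 the change is pentyl in place of hydrogen on an aromatic carbon, and the step that the two limits leave unreadable from compound 1 to compound 2 cannot be read because of the limit of > 20000 nM in this assay, at which 3 of the 3 values shown sit. The same change, (pentyl in place of hydrogen on an aromatic carbon), carries compound 3 to compound 4. For compound 4 the step that the limit leaves unreadable from compound 3 to compound 4 is expected to be unreadable in the same way, resting on the limit of compound 3 > 20000 nM. Compound 4 is therefore estimated at 40000 nM.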

Compound 4, half-maximal inhibitory concentration: > 20000 nM
Compound 4 was reported as a limit; the forecaster's own chance of this, stated with the estimate: 80%; the middle value does not contradict the limit.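

No new step can be read from compound 3 to compound 4 in this assay, because both compounds give only a limit: the limit of > 20000 nM in this assay, at which 4 of the 4 values shown sit.

The compounds shown leave open how strongly any of them inhibits, and whether pentyl in place of hydrogen changes that at all.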